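The source may report more compounds than this note shows. Statements on the series, on what has been measured and on what is new or still open speak of the compounds shown alone.

Measured so far in a functional assay on HL-60 cells (Homo sapiens) for cytotoxicity, read by luminescence and CellTiter-Glo, with a stated time of 3 days; on this read-out lower numbers stand for stronger inhibition and higher numbers for weaker inhibition:
compound 1 `O=C(Nc1ccc(OC(F)(F)F)cc1)c1cc(F)ccc1O` gives 850 nM
compound 2 `N#Cc1ccc(NC(=O)c2ccc(Br)cc2O)cc1Cl` gives 440 nM

Compound 2 at 440 nM lies within the usual scatter of compound 1 at 850 nM and so does not stand apart from it on these two numbers.

Compound 3 `N#Cc1ccc(NC(=O)c2ccc(Br)cc2O)cc1` has not been measured yet. It departs from compound 2 by hydrogen in place of chloro on an aromatic carbon with hydrogen in place of chloro on an aromatic carbon, ortho to a cyano group and meta to a large group.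

Among the measured compounds shown here, no measured pair isolates this change, so the series gives no direct size for it. Compound 1 at 850 nM and compound 2 at 440 nM differ in more than one place and still sit within the scatter of each other, which argues against expecting a large step in this assay here. A modest move toward weaker inhibition is expected, possibly not beyond the scatter. The expected size is a 1.8-fold higher number from compound 2 to compound 3 (0.26 log units; within the scatter) in the direction of a higher number. Compound 3 is estimated at 800 nM with 280 nM to 2300 nM as the expected range.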

Compound 3, half-maximal inhibitory concentration: 1210 nM
Beside the measured number, compound 3's estimate is 1.5-fold (0.18 log units) below it, within the range that was stated.
By their numbers in this assay, from the lowest: compounds 2, 1 and 3 (each within the scatter of the next, the first and the last beyond it).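

In this assay, among the compounds shown here, the chloro on the aromatic carbon ortho to a cyano group and meta to a large group now has a measured contribution, with hydrogen in its place giving a 2.8-fold higher number from compound 2 to compound 3 (0.44 log units; beyond the scatter) in the first comparison that isolates a single place. The change involves one heavy atom, no ring, no hydrogen-bond donor or acceptor and no net charge, yet the modest step lies beyond the scatter, so the identity of the group at this position registers in this read-out. No supporting measurement bears on why the number moves, so the step stands as a size without an explanation.

Chloro and hydrogen are the only two groups compared at this position, so it remains open whether a fluoro, a methyl, a methoxy or an amine there would give a number close to that of compound 2, close to that of compound 3, or outside both. On these data alone, with this single step, it is also open whether the chloro-to-hydrogen change would have a similar size on a compound with other groups elsewhere on the core, such as a fluoro in place of the bromo.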